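A few compounds are considered here, and "the series" means these few. Any claim that something is new, unique, unknown or untested is made for them only; others in the source may bear on it.

Compound 1 `Cc1ccc(Cn2c(/C=C3\SC(=S)N(CC(=O)O)C3=O)nc3cc(F)ccc32)cc1` and compound 2 `Cc1ccc(Cn2c(/C=C3\SC(=S)NC3=O)nc3ccccc32)cc1` share a common frame, but the difference between their two cores is not broken down here. In a functional assay on MDA-MB-231 cells (Homo sapiens) for cytotoxicity, read by MTT assay, with a stated time of 48 h (a higher number here means a weaker inhibitor, a lower number a stronger inhibitor), compound 1 gives 6550 nM, and compound 2 gives 6420 nM, the two values lying within the scatter of each other. Compound 3 `O=C(O)CN1C(=O)/C(=C/c2nc3cc(F)ccc3n2Cc2ccccc2F)SC1=S` carries 2-fluorophenyl in place of 4-methylphenyl on a saturated chain carbon bound to an aromatic nitrogen; this produces a 3.4-fold higher number from compound 1 to compound 3 (0.53 log units; beyond the scatter), so that compound 3 gives 22400 nM. Compound 4 `O=C1NC(=S)S/C1=C\c1nc2ccccc2n1Cc1ccccc1F` makes the same change on the core of compound 2, namely (2-fluorophenyl in place of 4-methylphenyl on a saturated chain carbon bound to an aromatic nitrogen). The step from compound 2 to compound 4 is expected to be about a 3.1-fold higher number from compound 2 to compound 4 (0.49 log units; beyond the scatter) in this assay, an expectation resting on a 3.4-fold higher number from compound 1 to compound 3 (0.53 log units; beyond the scatter) observed on the other core. Compound 4 is therefore expected to give around 20000 nM, most likely between 8000 nM and 50000 nM.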

Compound 4, half-maximal inhibitory concentration: 21300 nM
The estimate for compound 4 lay 1.1-fold (0.03 log units) below the measured number; the range from low to high includes it.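

In this assay, putting 2-fluorophenyl in place of 4-methylphenyl gives a 3.3-fold higher number from compound 2 to compound 4 (0.52 log units; beyond the scatter), and the step carries from one core to the other with its size preserved: the same change on two cores in this assay, a 3.4-fold higher number (0.53 log units; beyond the scatter) from compound 1 to compound 3 and a 3.3-fold higher number (0.52 log units; beyond the scatter) from compound 2 to compound 4, 1.0-fold (0.01 log units) apart, within the scatter of two such steps. On these two pairs, the change therefore reads the same on both cores in this one cell assay. This does not show why the number rises, nor that the step would hold on any further core or in any other assay.

The compounds shown leave open how other groups would read at this place on a saturated chain carbon bound to an aromatic nitrogen. An unsubstituted phenyl, an amine or a longer chain could each be tried there.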